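Bromo for methoxy on the shared core, cytotoxicity estimate

The source may report more compounds than this note shows. Statements on the series, on what has been measured and on what is new or still open speak of the compounds shown alone.

Measured so far:
compound 1 `O=C(CCCCC1CCSS1)NCc1cn(CCCOc2ccc3ccc(=O)oc3c2)nn1`: 37.2%
compound 2 `O=C(CCCCC1CCSS1)NCc1cn(CCCOc2ccc3cc(-c4ccccc4)c(=O)oc3c2)nn1`: 31.9%
compound 3 `COc1ccc(-c2cc3ccc(OCCCn4cc(CNC(=O)CCCCC5CCSS5)nn4)cc3oc2=O)cc1`: 47.4%

In a functional assay on PC-12 cells (Rattus norvegicus) for cytotoxicity, read by MTT assay, with stated times of 3 h and 2 h, tested at 1 uM (on this read-out higher numbers stand for a stronger effect at the one concentration tested and lower numbers for a weaker effect), compound 3 gives the highest of the three numbers, with compound 1 nearer to it and compound 2 furthest. Compound 4 `O=C(CCCCC1CCSS1)NCc1cn(CCCOc2ccc3cc(-c4ccc(Br)cc4)c(=O)oc3c2)nn1` differs from compound 3 by bromo in place of methoxy on an aromatic carbon. The nearest measured step is a number 15.5 percentage points higher from compound 2 to compound 3 (beyond the scatter), and a number 5.3 percentage points lower from compound 1 to compound 2 (within the scatter) adds little. Among the measured compounds shown here, no measured step exchanges methoxy for bromo, so the size of the coming step is uncertain; a modest fall toward the level of compound 2, within or barely beyond the scatter, is expected, as a number 9.4 percentage points lower from compound 3 to compound 4 (within the scatter). Compound 4 is therefore estimated at 38%, between 26% and 50%.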

Compound 4, a percentage reported as activity, at one concentration (the size of the read-out at that concentration, not a potency): 42.8%
Beside the measured number, compound 4's estimate is 4.8 percentage points below it; the measured number falls inside the stated range.
By their numbers in this assay, from the lowest: compounds 2, 1, 4 and 3 (each within the scatter of the next, the first and the last beyond it).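

In this assay the step of a number 4.6 percentage points lower from compound 3 to compound 4 (within the scatter) shows that bromo can take the place of methoxy on this aromatic carbon, para to a large group, without a difference beyond the scatter. A second group at this place now also stands clear of the unsubstituted phenyl, with a number 10.9 percentage points higher from compound 2 to compound 4 (beyond the scatter) as the step. The 4-bromophenyl in place of hydrogen gives a number 5.6 percentage points higher from compound 1 to compound 4 (within the scatter) and so does not separate from compound 1.

From the compounds shown here alone, whether an amine or a carboxylic acid at this place would read the same remains open. No available evidence bears on these differences.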